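A few compounds are considered here, and "the series" means these few. Any claim that something is new, unique, unknown or untested is made for them only; others in the source may bear on it.

Compound 1 `O=[N+]([O-])c1ccc(CN2CCC(n3cc(CC(OCc4cc(-c5ccc(Br)cc5)no4)c4ccc(Br)cc4)nn3)CC2)cc1`, compound 2 `O=[N+]([O-])c1ccc(CN2CCC(n3cc(CC(OCc4cc(-c5ccc(F)cc5)no4)c4ccc(Br)cc4)nn3)CC2)cc1` and compound 3 `COc1ccc(-c2cc(COC(Cc3cn(C4CCN(Cc5ccc([N+](=O)[O-])cc5)CC4)nn3)c3ccc(Br)cc3)on2)cc1` share one core and differ only in the group carried on an aromatic carbon of the outer phenyl ring. In a functional assay on MCF7 cells (Homo sapiens) for cytotoxicity, with a stated time of 48 h (on this read-out higher numbers stand for weaker inhibition and lower numbers for stronger inhibition), compound 1 gives 4000 nM, compound 2 gives 7000 nM and compound 3 gives 4000 nM. The three numbers lie within the scatter of one another, so compound 3 cannot be separated from compound 1 or compound 2 on this read-out.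

Compound 4 `N#Cc1ccc(-c2cc(COC(Cc3cn(C4CCN(Cc5ccc([N+](=O)[O-])cc5)CC4)nn3)c3ccc(Br)cc3)on2)cc1` is the next variation at that aromatic carbon: cyano in place of methoxy on an aromatic carbon. Among the measured compounds shown here, the steps that bear on this change are the earlier swaps at the same aromatic carbon, no change at the digits printed from compound 1 to compound 3 (within the scatter) and a 1.8-fold lower number from compound 2 to compound 3 (0.24 log units; within the scatter), together with a 1.8-fold higher number from compound 1 to compound 2 (0.24 log units; within the scatter); none of them moved the number beyond the scatter. On that basis the step from compound 3 to compound 4 in this assay is expected to be a 1.1-fold higher number from compound 3 to compound 4 (0.05 log units; within the scatter), with no direction claimed beyond the scatter. Compound 4 is therefore estimated at 4500 nM, with a range from 1800 nM to 11000 nM.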

Compound 4, half-maximal inhibitory concentration: 3000 nM
For compound 4 the middle estimate is 1.5-fold (0.18 log units) above the measured one, and the stated range covers the measured number.
By their numbers in this assay, from the lowest: compounds 4, 1, 3 and 2 (each within the scatter of the next, the first and the last beyond it).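

In this assay, among the compounds shown here, the cyano group yields the first step at this aromatic carbon that clears the scatter, and it is a modest one: a 2.3-fold lower number from compound 2 to compound 4 (0.37 log units; beyond the scatter). The other two steps stay within the scatter, a 1.3-fold lower number from compound 3 to compound 4 (0.12 log units; within the scatter) and a 1.3-fold lower number from compound 1 to compound 4 (0.12 log units; within the scatter), so cyano cannot be separated from methoxy or bromo here, and the only separation at this position lies between the cyano and fluoro members. No evidence bearing on the cause of that gap is available.

The compounds shown leave open what an amine, a carboxylic acid or a longer alkoxy chain would do at this aromatic carbon. They also leave open whether the gap between the fluoro and cyano members would hold on repeated measurement, given its modest size.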